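The source may report more compounds than this note shows. Statements on the series, on what has been measured and on what is new or still open speak of the compounds shown alone.

Compound 1 `CC(=O)Nc1cccc(NC(=O)COc2ccc3c(=O)ccoc3c2)c1` gives 2500 nM in an assay on isolated protein for inhibition of Rho-associated protein kinase 1 (Homo sapiens), read by scintillation counting, radiometric assay and 33P incorporation, with a stated time of 40 min, in the presence of a further agent that is not named here; on this read-out higher numbers stand for weaker inhibition and lower numbers for stronger inhibition.
Compound 2 `Cc1ccc(C(=O)Nc2cccc(NC(=O)COc3ccc4c(=O)ccoc4c3)c2)cc1` gives 183 nM in this assay.
Compound 3 `CCc1ccc(C(=O)Nc2cccc(NC(=O)COc3ccc4c(=O)ccoc4c3)c2)cc1` gives 235 nM in this assay.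

Compound 3 stands second highest of the three numbers. Its nearest neighbour is compound 2: a 1.3-fold higher number from compound 2 to compound 3 (0.11 log units; within the scatter). Its furthest is compound 1: an 11-fold lower number from compound 1 to compound 3 (1.03 log units; beyond the scatter), a large step, as is a 14-fold lower number from compound 1 to compound 2 (1.14 log units; beyond the scatter). Compound 4 `CC(C)(C)c1ccc(C(=O)Nc2cccc(NC(=O)COc3ccc4c(=O)ccoc4c3)c2)cc1` is not yet measured; it differs from compound 3 by tert-butyl in place of ethyl on an aromatic carbon. The step that bears on this change most directly is a 1.3-fold higher number from compound 2 to compound 3 (0.11 log units; within the scatter), a growth of the same chain at the same place, which stayed within the scatter. A further growth there is therefore expected to give a step of about a 1.3-fold higher number from compound 3 to compound 4 (0.11 log units; within the scatter) in this assay, not clearly beyond the scatter. Compound 4 is estimated at 300 nM, with a range from 120 nM to 800 nM.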

Compound 4, half-maximal inhibitory concentration: 165 nM
Compound 4: middle estimate off by 1.8-fold (0.26 log units), on the high side; low and high end bracket the measured number.
By their numbers in this assay, from the lowest: compounds 4, 2 and 3 (each within the scatter of the next); then compound 1.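

At this place on the aromatic ring, tert-butyl in place of ethyl gives a 1.4-fold lower number from compound 3 to compound 4 (0.15 log units; within the scatter) and tert-butyl in place of methyl gives a 1.1-fold lower number from compound 2 to compound 4 (0.04 log units; within the scatter) in this assay, so even a branched group of four carbons cannot be told apart from the two smaller chains. The large step of a 15-fold lower number from compound 1 to compound 4 (1.18 log units; beyond the scatter) also extends to 4-(tert-butyl)phenyl, and compounds 2, 3 and 4 all share it. No measurement here offers a reason for this flat result. Still open, going by these compounds, is whether an amine, a carboxylic acid or a methoxy group at this place would keep these numbers.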